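Cytotoxicity notes on compounds 1 to 4

This account rests on a few compounds, and the source may have more. Where it says the series, first, only, none or still open, it means among the compounds named here.

Compound 1 `COC(=O)c1cc(-c2cccc(NC(=O)c3ccc(/C=C/C(=O)c4cc(OC)c(OC)c(OC)c4)cc3)c2)on1`, compound 2 `COC(=O)c1cc(-c2cccc(NC(=O)c3ccc(/C=C/C(=O)c4cc(F)ccc4F)cc3)c2)on1` and compound 3 `COC(=O)c1cc(-c2cccc(NC(=O)c3ccc(/C=C/C(=O)c4ccccc4OC)cc3)c2)on1` share one core and differ only in the aryl group on the carbonyl carbon. In an ADME assay on Vero cells (Chlorocebus sabaeus) for cytotoxicity, read by MTT assay, with a stated time of 72 h (on this read-out higher numbers stand for lower toxicity in this test and lower numbers for higher toxicity in this test), compound 1 gives > 50 ug/mL, a limit of the test rather than a number. In this assay compound 2 gives > 40 ug/mL, again a limit. In this assay compound 3 gives > 40 ug/mL, also a limit. The steps a step that the two limits leave unreadable from compound 1 to compound 2, a step that the two limits leave unreadable from compound 1 to compound 3 and a step that the two limits leave unreadable from compound 2 to compound 3 carry no readable size. Compound 3 stands at the limit of > 40 ug/mL in this assay, at which 2 of the 3 values shown sit. Compound 1 alone sits at the limit of > 50 ug/mL in this assay, at which 1 of the 3 values shown sits. Compound 4 `COC(=O)c1cc(-c2cccc(NC(=O)c3ccc(/C=C/C(=O)c4ccc(F)cc4)cc3)c2)on1` differs from compound 3 by 4-fluorophenyl in place of 2-methoxyphenyl on a carbonyl carbon. For the measured compounds named here, no measured step bears on this change with a readable size; every value so far is a limit, so no shift beyond the scatter is expected in this assay. The step from compound 3 to compound 4 is estimated as a step that the limit leaves unreadable from compound 3 to compound 4. Compound 4 is expected to give about 50 ug/mL, between 30 ug/mL and 100 ug/mL, most likely reported again as a limit.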

Compound 4, half-maximal cytotoxic concentration: > 20 ug/mL
Compound 4 ended at the assay's limit; the forecaster's own chance of this, stated with the estimate: 80%; the middle value lies beyond the limit too.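

In this assay compound 4 gives > 20 ug/mL, a limit and not a number. For the compounds shown here, no step linking compound 4 with compound 1, compound 2 or compound 3 can be read. The compounds shown leave open whether changing the aryl group on the carbonyl carbon shifts the half-maximal cytotoxic concentration at all.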